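Benzylamine sulfonamides on pancreatic cells: next analogue

A few compounds are considered here, and "the series" means these few. Any claim that something is new, unique, unknown or untested is made for them only; others in the source may bear on it.

Measured so far:
- Compound 1, `CC(C)(C)c1ccc(CNCCNS(=O)(=O)c2cc(C(F)(F)F)cc(C(F)(F)F)c2)cc1`: in a functional assay on ASPC1 cells (Homo sapiens) for inhibition, read by MTT assay, with a stated time of 72 h (on this read-out lower numbers stand for stronger inhibition of growth and higher numbers for weaker inhibition of growth), compound 1 gives 14000 nM.
- Compound 2, `O=S(=O)(NCCCCNCc1ccc(Br)cc1)c1cc(C(F)(F)F)cc(C(F)(F)F)c1`: in this assay compound 2 gives 2900 nM.
- Compound 3, `COc1cccc(CNCCCNS(=O)(=O)c2cc(C(F)(F)F)cc(C(F)(F)F)c2)c1`: in this assay compound 3 gives 3800 nM.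

Compound 3 holds the second highest of the three numbers. Its nearest neighbour is compound 2, a 1.3-fold higher number from compound 2 to compound 3 (0.12 log units; within the scatter), so these two cannot be ordered. Compound 1 lies furthest off, with a number beyond the scatter from that of compound 3.

The next analogue is compound 4, `O=S(=O)(NCCCNCc1ccc(Br)cc1)c1cc(C(F)(F)F)cc(C(F)(F)F)c1`. Relative to compound 3 the change is 4-bromophenyl in place of 3-methoxyphenyl on a saturated chain carbon bound to an amine nitrogen.

Among the measured compounds shown here, the only measured step that bears on this change is the one between compound 2 and compound 3, which swaps the same two benzylamino groups in the opposite direction, though on a chain of different length: a 1.3-fold higher number from compound 2 to compound 3 (0.12 log units; within the scatter). That step stayed within the scatter. On that basis no step beyond the scatter is expected from compound 3 to compound 4 in this assay, at most a slight shift toward the number of compound 2; the estimated step is a 1.3-fold lower number from compound 3 to compound 4 (0.10 log units; within the scatter).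

Compound 4 is therefore estimated at 3000 nM, with a range from 1400 nM to 6500 nM.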

Compound 4, concentration for 50% growth inhibition: 2800 nM
Compound 4: the middle estimate sits 1.1-fold (0.03 log units) above what was measured, and the stated range covers the measured number.
By their numbers in this assay, from the lowest: compounds 4, 2 and 3 (each within the scatter of the next); then compound 1.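

With the chain of compound 3 kept, 4-bromophenyl in place of 3-methoxyphenyl on a saturated chain carbon bound to an amine nitrogen can now be read in this assay without a chain difference alongside it (a 1.4-fold lower number from compound 3 to compound 4 (0.13 log units; within the scatter)). With the 4-bromobenzyl group kept, (4-bromobenzyl)amino in place of ((4-bromobenzyl)amino)methyl gives a separate reading of the chain difference (a 1.0-fold lower number from compound 2 to compound 4 (0.02 log units; within the scatter)), so neither single change separates the compounds in these pairs beyond the scatter. No measurement on hand accounts for either step.

Compound 1 differs from compound 4 in both the chain and the benzyl group, so the pairs shown do not assign its separation from compound 3 to either place, and a 4-bromobenzyl group on the chain of compound 1 would address that question directly. Also open, as far as these compounds go, is whether a group of another kind on this benzyl ring, such as a nitrile or a carboxylic acid, or a longer chain than those in compound 2 and compound 4, would give a step beyond the scatter.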